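This account rests on a few compounds, and the source may have more. Where it says the series, first, only, none or still open, it means among the compounds named here.

Measured so far:
Compound 1, `O=C(O)CCCCCCOc1cc(-c2ccccc2)c2ccccc2n1`: in an assay on membranes from spleen (Cavia porcellus) for binding affinity to leukotriene B4 receptor 1 (Homo sapiens) (a higher number here means a weaker inhibitor, a lower number a stronger inhibitor), compound 1 gives 1800 nM.
Compound 2, `O=C(O)CCCCCOc1cc(-c2ccccc2)c2ccccc2n1`: in this assay compound 2 gives 700 nM.
Compound 3, `CC(C)(CCCCOc1cc(-c2ccccc2)c2ccccc2n1)C(=O)O`: in this assay compound 3 gives 183 nM.

Compound 3 holds the lowest number of the three. Its nearest neighbour is compound 2, and the step there is a 3.8-fold lower number from compound 2 to compound 3 (0.58 log units; beyond the scatter); the furthest is compound 1, with a 9.8-fold lower number from compound 1 to compound 3 (0.99 log units; beyond the scatter). Compound 4, `CC(CCCCOc1cc(-c2ccccc2)c2ccccc2n1)C(=O)O`, has not been measured. It differs from compound 3 in one place: hydrogen in place of methyl on a saturated chain carbon bound to a carbonyl carbon and two saturated chain carbons. The group carrying the acid thus goes from 1-carboxy-1-methylethyl to 1-carboxyethyl, so compound 4 sits structurally between compound 2, which carries carboxymethyl, and compound 3. The step that bears most directly on this is a 3.8-fold lower number from compound 2 to compound 3 (0.58 log units; beyond the scatter), a modest gain; the step of a 2.6-fold lower number from compound 1 to compound 2 (0.41 log units; beyond the scatter) concerns chain length rather than branching and bears less. Taking away one methyl is therefore expected to give back part of that gain. Compound 4 is expected to show about 330 nM in this assay, within a range from 160 nM to 700 nM. The expected step is a 1.8-fold higher number from compound 3 to compound 4 (0.26 log units; within the scatter), near the edge of the scatter.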

Compound 4, half-maximal inhibitory concentration: 550 nM
Estimate against measurement, compound 4: 1.7-fold (0.22 log units) below; measured number inside the range.
By their numbers in this assay, from the lowest: compound 3; then compounds 4 and 2 (each within the scatter of the next); then compound 1.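

Taking one methyl off the chain carbon bound to the carbonyl carbon is a real loss, with a 3.0-fold higher number from compound 3 to compound 4 (0.48 log units; beyond the scatter) in this assay, so the advantage of the 1-carboxy-1-methylethyl group does not survive in 1-carboxyethyl. A single methyl alone gives no readable gain over the unbranched acid, at a 1.3-fold lower number from compound 2 to compound 4 (0.10 log units; within the scatter), so among these compounds the clear gain appears only with both methyls in place, although 1-carboxyethyl in place of 2-carboxyethyl still gives a 3.3-fold lower number from compound 1 to compound 4 (0.51 log units; beyond the scatter) as a separate comparison. Nothing available explains why the second methyl counts for more than the first.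

Open, as far as these compounds go, is whether ethyl in place of methyl on that carbon would keep the number of compound 3 or lose it. Also open, from the compounds shown here alone, is how a tetrazole in place of the carboxylic acid would read on the same chain.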